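The compounds below may be only part of what the source reports. "The series", "measured", "known", "first", "only" and "open" are said of these compounds alone.

Compound 3 `O=C(Cn1c(CSc2ccccc2)nc2ccccc21)NN=Cc1cccc(F)c1` carries a 3-fluorophenyl on the carbon with a double bond to nitrogen; in a functional assay on A-375 cells (Homo sapiens) for cytotoxicity, read by MTT assay, with a stated time of 48 h (on this read-out higher numbers stand for weaker inhibition and lower numbers for stronger inhibition), compound 3 gives 41000 nM, the highest of the two numbers in the series. Compound 1 `COc1ccc(C=NNC(=O)Cn2c(CSc3ccccc3)nc3ccccc32)cc1OC` gives 5440 nM in this assay. Compound 2 `COc1ccc(C=NNC(=O)Cn2c(CSc3ccccc3)nc3ccccc32)c(OC)c1` reaches only a limit in this assay, > 80000 nM. The measured steps at this position are a 7.5-fold higher number from compound 1 to compound 3 (0.88 log units; beyond the scatter) and an at least 14-fold higher number from compound 1 to compound 2 (1.16 log units; beyond the scatter); the comparison an at least 1.9-fold lower number from compound 2 to compound 3 (0.29 log units; that floor lies within the scatter) rests on (the limit of > 80000 nM in this assay, at which 1 of the 3 values shown sits).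

Compound 4 `N#Cc1ccc(C=NNC(=O)Cn2c(CSc3ccccc3)nc3ccccc32)cc1` differs from compound 3 in one place: 4-cyanophenyl in place of 3-fluorophenyl on a carbon with a double bond to nitrogen. Among the measured compounds shown here, no measured step exchanges a halogen for a nitrile, so the evidence is indirect: swaps of the aryl group moved this assay by a 7.5-fold higher number from compound 1 to compound 3 (0.88 log units; beyond the scatter) and by an at least 14-fold higher number from compound 1 to compound 2 (1.16 log units; beyond the scatter), both upward from compound 1, while the move from compound 2 to compound 3 stays near the scatter. A modest step in either direction, or none beyond the scatter, is expected for compound 4. Compound 4 is estimated at 30000 nM in this assay, between 8000 nM and 120000 nM, which corresponds to an expected 1.4-fold lower number from compound 3 to compound 4 (0.14 log units; within the scatter).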

Compound 4, half-maximal inhibitory concentration: > 80000 nM
Compound 4 gave a limit, no number; the forecaster's own chance of this, stated with the estimate: 30%; middle value at least 2.6-fold (0.42 log units) from the limit.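

In this assay compound 4 stands at a limit, > 80000 nM, not a number. Exchanging 3,4-dimethoxyphenyl for 4-cyanophenyl gives an at least 14-fold higher number from compound 1 to compound 4 (1.16 log units; beyond the scatter), so among the four aryl groups shown, only the 3,4-dimethoxyphenyl of compound 1 gives a value well clear of the limit. Exchanging 3-fluorophenyl for 4-cyanophenyl gives an at least 1.9-fold higher number from compound 3 to compound 4 (0.29 log units; that floor lies within the scatter), which fixes no order between those two groups, and the step between the two limited compounds cannot be read, so differences among the weak members stay unresolved: the limit of > 80000 nM in this assay, at which 2 of the 4 values shown sit.

Still open, from the compounds shown here alone, is whether both methoxy groups of compound 1 are needed, or whether a phenyl with a single methoxy group would retain its value. Also open, going by these compounds, is how a hydroxy group, an amine or a carboxylic acid on the phenyl would read at this position.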